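Swapping a furan for a nitrophenyl: expected cytotoxicity

The source may report more compounds than this note shows. Statements on the series, on what has been measured and on what is new or still open speak of the compounds shown alone.

Three compounds sharing one core were measured in an ADME assay on J774.A1 cells (Mus musculus) for cytotoxicity, read by MTT assay, with a stated time of 72 h; on this read-out higher numbers stand for lower toxicity in this test and lower numbers for higher toxicity in this test. Compound 1 `CC1(Cc2ccccc2)CC(S(=O)(=O)c2cccc(F)c2)=C(c2ccc(/C(N)=N\O)cc2)O1` gives 28300 nM in this assay. Among the compounds with values here, compound 3 `CC1(Cc2ccccc2)CC(S(=O)(=O)c2ccccc2F)=C(c2ccc(/C(N)=N\O)cc2)O1` gives 29100 nM in this assay; the only measured single-point step, a 1.0-fold higher number from compound 1 to compound 3 (0.01 log units; within the scatter), shows that the two fluorophenyl groups on the sulfonyl sulfur give the same read-out. Compound 2 `CC1(c2ccc(-c3ccco3)cc2)CC(S(=O)(=O)c2ccc(F)cc2)=C(c2ccc(/C(N)=N\O)cc2)O1` gives 4560 nM in this assay, the lowest of the three numbers, its gap to compound 1 and to compound 3 each lying beyond the scatter.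

Compound 4 `CC1(c2ccc(-c3cccc([N+](=O)[O-])c3)cc2)CC(S(=O)(=O)c2ccc(F)cc2)=C(c2ccc(/C(N)=N\O)cc2)O1` differs from compound 2 by a single change: 3-nitrophenyl in place of furan-2-yl on an aromatic carbon. Within the data shown here, no measured step touches this position; the one measured step, a 1.0-fold higher number from compound 1 to compound 3 (0.01 log units; within the scatter), concerns the fluorophenyl on the sulfonyl sulfur and says nothing about a group para to a large group. With nothing to steer the expectation either way, compound 4 is expected to stay close to compound 2 in this assay. The step expected, a 1.0-fold lower number from compound 2 to compound 4 (0.01 log units; within the scatter), is none beyond the scatter. Compound 4 is therefore estimated at 4500 nM in this assay, within a range of 1500 nM to 14000 nM.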

Compound 4, half-maximal cytotoxic concentration: 11100 nM
Estimate against measurement, compound 4: 2.5-fold (0.39 log units) below; low and high end bracket the measured number.
By their numbers in this assay, from the lowest: compound 2; then compound 4; then compounds 1 and 3 (each within the scatter of the next).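

In this assay, the group on this aromatic carbon, para to a large group, does affect the read-out: with 3-nitrophenyl in place of furan-2-yl, the result is a 2.4-fold higher number from compound 2 to compound 4 (0.39 log units; beyond the scatter), a modest shift towards lower toxicity in this test. Within the data shown here, this is the first measured step at this position, as the earlier step concerned only the fluorophenyl on the sulfonyl sulfur. No available evidence accounts for this step.

As far as these compounds go, a single pair cannot separate the change of ring from the arrival of the nitro group, so it remains open how a plain phenyl, or a phenyl bearing an amine or a carboxylic acid, would read here. From the compounds shown here alone, it is also open whether the same swap would give a similar step with 2-fluorophenyl or 3-fluorophenyl on the sulfonyl sulfur.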